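A large new group on a flat series

This account rests on a few compounds, and the source may have more. Where it says the series, first, only, none or still open, it means among the compounds named here.

Measured in an ADME assay on HEK293 cells (Homo sapiens) for cytotoxicity, read by CellTiter-Glo, with a stated time of 72 h; a lower number here means that less compound is needed, a higher number that more compound is needed for the effect:
Compound 1 `C[C@@H]1CC[C@H]2CC3C(=O)CC[C@@]31C2(C)C`: 26000 nM
Compound 2 `CC1=C2CC(C)(C)/C=C/C/C(C)=C\C3=C[C@H](C)C[C@]3(O2)C1=O`: 26000 nM
Compound 3 `CC(=O)O[C@@H]1/C=C/C(C)(C)CC2=C(C)C(=O)[C@]3(C[C@@H](C)C=C3/C=C\1C)O2`: 26000 nM

In this assay, within the data shown here, compound 2 gives 26000 nM and stands level with compound 1 and compound 3, so the numbers so far show no spread at all. The change leading to compound 4 `CC1=C2CC(C)(C)/C=C/[C@H](OC(=S)Sc3ccccc3)/C(C)=C\C3=C[C@H](C)C[C@]3(O2)C1=O` is a group of 10 heavy atoms (7 carbon, 1 oxygen, 2 sulfur; one six-membered aromatic ring of carbon only) in place of a hydrogen atom, on a saturated ring carbon. It sits on a saturated ring carbon, next to the ring atom that bears a methyl group.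

Among the measured compounds shown here, one measured step bears on this directly. Acetoxy in place of hydrogen on a saturated ring carbon, which leads to compound 3, gave no change at the digits printed from compound 2 to compound 3 (within the scatter). That step suggests that substitution on such a carbon need not move the value in this assay, and no step beyond the scatter is therefore expected. For the measured compounds named here, the guide is thin, however: the entering group is larger than acetoxy, and no measured compound carries sulfur or a six-membered aromatic ring. The range is therefore kept wide and reaches further toward lower values.

The expected result is a 1.2-fold lower number from compound 2 to compound 4 (0.07 log units; within the scatter). For compound 4 the estimated value is 22000 nM, with an expected range of 9000 nM to 40000 nM.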

Compound 4, half-maximal effective concentration: 26000 nM
Compound 4: middle estimate off by 1.2-fold (0.07 log units), on the low side; low and high end bracket the measured number.
By their numbers in this assay, from the lowest: compounds 1, 2, 3 and 4 (each within the scatter of the next).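

In this assay, a group of 10 heavy atoms, on a saturated ring carbon next to the ring atom that bears a methyl group, gave no change at the digits printed from compound 2 to compound 4 (within the scatter). Until now the only substituent seen on this carbon was the acetoxy group of compound 3, so the new result extends the flat reading to a much larger group, one that carries two sulfur atoms and one six-membered aromatic ring of carbon only, while the number stays the same at the digits printed. Nothing measured here accounts for this lack of response, and the result alone gives no reason for it.

What remains open is whether any group on this carbon can move the number, since both substituents seen here are uncharged and neither an amine nor a carboxylic acid appears among the compounds shown. From the compounds shown here alone, it is also open whether changes elsewhere on the shared core, such as replacing the ring oxygen or the carbonyl, would leave the value equally unmoved.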